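The source may report more compounds than this note shows. Statements on the series, on what has been measured and on what is new or still open speak of the compounds shown alone.

Compound 1 `CCn1c(=O)n(-c2cc(OC)c(OC)c(OC)c2)c2cc(-c3ccc(OC)c(O)c3)ncc21`: > 20000 nM
Compound 2 `COc1ccc(-c2cc3c(cn2)n(C2CC2)c(=O)n3-c2cc(OC)c(OC)c(OC)c2)cc1O`: > 20000 nM

The test here is a functional assay on A2780 cells (Homo sapiens) for antiproliferative activity, read by MTT assay, with a stated time of 48 h; on this read-out lower numbers stand for stronger inhibition and higher numbers for weaker inhibition. In this assay compound 1 gives > 20000 nM, which is a limit and not a number. In this assay, from the compounds shown here alone, compound 2 gives > 20000 nM, again a limit, so its true potency is unknown and it has no measured standing beyond that limit.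

Going by the values given here, the one measured change, cyclopropyl in place of ethyl on an aromatic nitrogen, is a step that the two limits leave unreadable from compound 1 to compound 2. All the data so far amount to the limit of > 20000 nM in this assay, at which 2 of the 2 values shown sit.

Compound 3 `COc1ccc(-c2cc3c(cn2)n(CC(N)=O)c(=O)n3-c2cc(OC)c(OC)c(OC)c2)cc1O` keeps the core of compound 2 and has carbamoylmethyl in place of cyclopropyl on an aromatic nitrogen.

Among the compounds with values here, no measured step gives a size to carry over, and no step here involves carbamoylmethyl. The expectation therefore rests on compound 2, with its > 20000 nM, and a clear gain in this assay is not expected. The expected change is a number no higher from compound 2 to compound 3 (the limit leaves the size open), and this estimate is uncertain. For compound 3 the estimated value is 20000 nM, with an expected range from 6000 nM to 40000 nM.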

Compound 3, half-maximal inhibitory concentration: 9880 nM
Compound 3: middle estimate off by 2.0-fold (0.31 log units), on the high side; the range from low to high includes it.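

In this assay, going by these compounds alone, compound 3 gives 9880 nM, the only true number among the three compounds, which shows that a group on this aromatic nitrogen can bring the read-out into the measurable range. Carbamoylmethyl in place of cyclopropyl gives an at least 2.0-fold lower number from compound 2 to compound 3 (0.30 log units; that floor lies within the scatter), and carbamoyl in place of methyl on the saturated chain carbon bound to that nitrogen gives an at least 2.0-fold lower number from compound 1 to compound 3 (0.30 log units; that floor lies within the scatter); both sizes are only floors, and the real gaps may be wider. The step between compound 1 and compound 2 cannot be read, and neither compound gives more than a limit of the assay: the limit of > 20000 nM in this assay, at which 2 of the 3 values shown sit.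

The compounds shown leave open which part of carbamoylmethyl matters, the carbonyl or the amide hydrogen, and how much lower the number can go at this position. A carboxylic acid or an amine on the same short chain, or a longer chain ending in the carbamoyl group, would help to separate these possibilities.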